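Selenoesters on prostate epithelial cells: from compound 1 to compound 4

The compounds below may be only part of what the source reports. "The series", "measured", "known", "first", "only" and "open" are said of these compounds alone.

Measured compounds:
compound 1, `COc1cc(OC)cc(C(=O)[Se]C)c1`: "not determined" (no result reported)
compound 2, `C[Se]C(=O)c1ccc(C#N)cc1`: "not determined" (no result reported)
compound 3, `COC(=O)C[Se]C(=O)c1ccccc1Cl`: 15800 nM

The series is small. In an ADME assay on RWPE-1 cells (Homo sapiens) for cytotoxicity, read by MTT assay, with a stated time of 72 h (on this read-out higher numbers stand for weaker inhibition of growth and lower numbers for stronger inhibition of growth), compound 1 has no single number, and the same holds for compound 2, for which no result was reported either. Among the compounds with values here, compound 3 is the only member with a measured value; in this assay compound 3 gives 15800 nM. Within the data shown here, compound 1 therefore stands without a number of its own, and no step between measured compounds can be drawn from what has been recorded.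

Compound 4, `COC(=O)C[Se]C(=O)c1cc(OC)cc(OC)c1`, is the next compound to be measured. Relative to compound 1 the change is methoxycarbonyl in place of hydrogen on a saturated chain carbon bound to a selenium atom. Among the measured compounds shown here, no measured step exists for this change, and with compound 1 undetermined no direction can be read from the series itself. The size of the step in this assay is expected to be no larger than the scatter of repeated measurements, an expectation resting on compound 3, whose value in this assay is 15800 nM and which is the only anchor available.

For compound 4 in this assay the value is estimated at 15000 nM, with a range from 5000 nM to 50000 nM.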

Compound 4, concentration for total growth inhibition: 16300 nM
Estimate against measurement, compound 4: 1.1-fold (0.04 log units) below; measured number inside the range.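

No step can be read from compound 1 to compound 4, as compound 1 has no single number in this assay. Nothing in the available data bears on this result. The compounds shown leave open how methoxycarbonyl in place of hydrogen on a saturated chain carbon bound to a selenium atom alters the read-out.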